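Replacing thiomorpholin-4-yl in compound 3

The source may hold more compounds than are shown below. What is called first, only, known or untested is meant among the compounds shown, and "the series" means these compounds.

- compound 1 `CCCCc1nc(C)c(CC(=O)O)c(=O)n1Cc1ccc(-c2ccccc2-c2nnn[nH]2)cc1`: 0.13 mg/kg
- compound 2 `CCCCc1nc(C)c(CCC(=O)N2CCC[C@H]2C(=O)OC)c(=O)n1Cc1ccc(-c2ccccc2-c2nnn[nH]2)cc1`: 0.063 mg/kg
- compound 3 `CCCCc1nc(C)c(CCC(=O)N2CCSCC2)c(=O)n1Cc1ccc(-c2ccccc2-c2nnn[nH]2)cc1`: 0.204 mg/kg

All three values come from an in vivo functional assay on the whole organism for inhibition, with Rattus norvegicus as the target; on this read-out higher numbers stand for an effect only at larger amounts of compound and lower numbers for an effect already at smaller amounts. Compound 3 gives 0.204 mg/kg there, the largest number of the three, but that does not set it clearly apart from every neighbour. The data show a 1.6-fold higher number from compound 1 to compound 3 (0.20 log units; within the scatter), and also a 3.2-fold higher number from compound 2 to compound 3 (0.51 log units; beyond the scatter).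

The next compound, compound 4 `CCCCc1nc(C)c(CCC(=O)N2CC(C)OC(C)C2)c(=O)n1Cc1ccc(-c2ccccc2-c2nnn[nH]2)cc1`, carries 2,6-dimethylmorpholin-4-yl in place of thiomorpholin-4-yl on a carbonyl carbon. Both groups are six-membered non-aromatic rings.

Among the measured compounds shown here, the most relevant measured step is a 3.2-fold higher number from compound 2 to compound 3 (0.51 log units; beyond the scatter), the only one that exchanges one group for another on this carbonyl carbon. It shows that a swap at this place can shift the number modestly, but it involves a different kind of group and gives no direction for the present change. The step of a 2.1-fold lower number from compound 1 to compound 2 (0.31 log units; beyond the scatter) replaces the carboxy group instead, so it bears on this change only loosely.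

With no direction to go on, the expectation is no step beyond the scatter: a 1.1-fold lower number from compound 3 to compound 4 (0.05 log units; within the scatter). Compound 4 is estimated at 0.18 mg/kg, with an expected range from 0.06 mg/kg to 0.5 mg/kg.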

Compound 4, dose for half-maximal effect: 0.228 mg/kg
Estimate against measurement, compound 4: 1.3-fold (0.10 log units) below, and the stated range covers the measured number.
By their numbers in this assay, from the lowest: compound 2; then compounds 1, 3 and 4 (each within the scatter of the next).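

In this assay, putting 2,6-dimethylmorpholin-4-yl in place of thiomorpholin-4-yl on the carbonyl carbon gives a 1.1-fold higher number from compound 3 to compound 4 (0.05 log units; within the scatter), so at this place a ring with more heavy atoms, oxygen instead of sulfur and two added methyl groups reads the same as the first ring. The second six-membered ring also repeats the picture seen with compound 3: there is a 3.6-fold higher number from compound 2 to compound 4 (0.56 log units; beyond the scatter), which leaves compound 2 apart, whereas a 1.8-fold higher number from compound 1 to compound 4 (0.24 log units; within the scatter) stays close to the carboxy compound. Nothing measured on these compounds gives a reason for these readings.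

Because the oxygen and the two methyl groups arrive together, the compounds shown cannot separate their contributions, and unsubstituted morpholin-4-yl or 2,6-dimethylpiperidin-1-yl on the same carbonyl carbon would be needed to pull them apart. On these data alone, it also remains open whether compound 2 stands apart through its five-membered ring or through its methyl ester, a question that plain pyrrolidin-1-yl or the matching 2-carboxypyrrolidin-1-yl could address.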